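The source may report more compounds than this note shows. Statements on the series, on what has been measured and on what is new or still open speak of the compounds shown alone.

Working notes on the series. Among the compounds with values here, compound 2 `COc1ccc2c(OCC[C@@H]3NC(=O)N(C)CCCC/C=C\[C@@H]4C[C@@]4(C(=O)NS(=O)(=O)N4CCOCC4)NC3=O)cc(-c3nc(C(C)C)cs3)nc2c1Cl` carries a morpholin-4-yl group on the sulfonyl sulfur; in an ADME assay on cells (Homo sapiens) for activation (a lower number here means that less compound is tolerated, a higher number that more compound is tolerated), compound 2 gives 26400 nM, the only plain number so far in this read-out. Compound 1 `COc1ccc2c(OCC[C@@H]3NC(=O)N(C)CCCC/C=C\[C@@H]4C[C@@]4(C(=O)NS(=O)(=O)C4(C#N)CC4)NC3=O)cc(-c3nc(C(C)C)cs3)nc2c1Cl` differs from it only at that sulfur, bearing a 1-cyanocyclopropyl group instead. In this assay compound 1 reports a limit, > 75000 nM. Within the data shown here, the one measured step, an at least 2.8-fold lower number from compound 1 to compound 2 (0.45 log units; beyond the scatter), is known only as a minimum because it rests on (the limit of > 75000 nM in this assay, at which 1 of the 2 values shown sits). Compound 3 `C#CC1(S(=O)(=O)NC(=O)[C@@]23C[C@H]2/C=C\CCCCN(C)C(=O)N[C@@H](CCOc2cc(-c4nc(C(C)C)cs4)nc4c(Cl)c(OC)ccc24)C(=O)N3)CC1` is not yet measured; its change from compound 2 is 1-ethynylcyclopropyl in place of morpholin-4-yl on a sulfonyl sulfur. This step runs opposite in sense to the measured one, putting a 1-ethynylcyclopropyl group where the measured pair had the 1-cyanocyclopropyl group, a triple bond in place of the nitrile. From that single precedent a higher number is expected, about a 2.3-fold higher number from compound 2 to compound 3 (0.36 log units; beyond the scatter), with a fair chance that only a limit is returned. Compound 3 is therefore estimated at 60000 nM, within 26000 nM to 120000 nM.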

Compound 3, half-maximal cytotoxic concentration: 26300 nM
The estimate for compound 3 lay 2.3-fold (0.36 log units) above the measured number; the range from low to high includes it.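

In this assay, 1-ethynylcyclopropyl in place of morpholin-4-yl on the sulfonyl sulfur makes no difference beyond the scatter, a 1.0-fold lower number from compound 2 to compound 3 (0.00 log units; within the scatter), so two groups that share little in the counted features read alike here. Ethynyl in place of cyano on a saturated ring carbon gives an at least 2.8-fold lower number from compound 1 to compound 3 (0.45 log units; beyond the scatter), so the cyclopropyl ring alone does not keep the read-out of compound 1, and among these compounds the nitrile-bearing group stands apart. This step is known only as a minimum because compound 1 reports a limit, not a number: the limit of > 75000 nM in this assay, at which 1 of the 3 values shown sits.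

On these data alone, the true size of the gap to compound 1 stays open. Also open, as far as these compounds go, is whether a methyl group on the same cyclopropyl carbon, or a dimethylamino group on the sulfonyl sulfur, would read with compound 2 and compound 3 or with compound 1.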